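Swapping methyl position on the benzyl ether of two cores

A few compounds are considered here, and "the series" means these few. Any claim that something is new, unique, unknown or untested is made for them only; others in the source may bear on it.

Measured so far:
- Compound 1, `Cc1cccc(COc2ccc(-c3nn(CCC#N)c(=O)o3)cc2)c1`, gives 20000 nM in an assay for inhibition of Amine oxidase [flavin-containing] A (Rattus norvegicus); on this read-out lower numbers stand for stronger inhibition and higher numbers for weaker inhibition.
- Compound 2, `Cc1ccc(COc2ccc(-c3nn(CCC#N)c(=O)o3)cc2)cc1`, gives 25000 nM in this assay.
- Compound 3, `Cc1cccc(COc2ccc(C3=NN(CCC#N)C(=O)CO3)cc2)c1`, gives 40000 nM in this assay.

Compounds 1 and 2 share one core and differ in a single spot: 4-methylphenyl in place of 3-methylphenyl on a saturated chain carbon bound to an oxygen on an aromatic ring. That change gave a 1.3-fold higher number from compound 1 to compound 2 (0.10 log units; within the scatter), so the two compounds cannot be told apart by this measurement. Compound 3 carries a different core; the difference between the two cores is not broken down here. Its value sits at the weak end of the three numbers, yet its gaps to compound 2 and to compound 1 are both within the scatter, so no order among the three can be claimed.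

Compound 4, `Cc1ccc(COc2ccc(C3=NN(CCC#N)C(=O)CO3)cc2)cc1`, is not yet measured. It stands to compound 3 exactly as compound 2 stands to compound 1: 4-methylphenyl in place of 3-methylphenyl on a saturated chain carbon bound to an oxygen on an aromatic ring. The place of the change is the same in both pairs, so this is the same change, seen twice among the compounds here. Because the earlier instance gave a 1.3-fold higher number from compound 1 to compound 2 (0.10 log units; within the scatter), the step from compound 3 to compound 4 is expected to be similarly small, about a 1.3-fold higher number from compound 3 to compound 4 (0.10 log units; within the scatter). On that basis compound 4 is estimated at 50000 nM in this assay, with a likely range from 20000 nM to 125000 nM.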

Compound 4, half-maximal inhibitory concentration: 250000 nM
The estimate for compound 4 lay 5.0-fold (0.70 log units) below the measured number, and the stated range ends below it.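

Moving the methyl group from 3-methylphenyl to 4-methylphenyl on the core of compound 3 in this assay gives a 6.3-fold higher number from compound 3 to compound 4 (0.80 log units; beyond the scatter), a step large enough to count as a real difference between the two compounds. The size of this step therefore cannot simply be carried from one core to the other, even though the change itself is identical and sits in the same place on both: the same change on two cores in this assay, a 1.3-fold higher number (0.10 log units; within the scatter) from compound 1 to compound 2 and a 6.3-fold higher number (0.80 log units; beyond the scatter) from compound 3 to compound 4, 5.0-fold (0.70 log units) apart, beyond the scatter of two such steps

This shows only that the effect of the change depends on the core in this pair of pairs; with a single example on each core, it does not show why the cores differ, or which of the two step sizes would be typical of other compounds in the series.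

The compounds shown leave open whether the same dependence on the core appears when a different group, such as a methoxy group or a chlorine atom, takes the place of the methyl group. They also leave open whether it survives when the chain ending in the nitrile is replaced by a longer chain or by one ending in a carboxylic acid or an amine.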